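Swapping the aryl group on a shared core

The compounds below may be only part of what the source reports. "The series", "measured", "known", "first", "only" and "open" are said of these compounds alone.

The measured compounds so far:
Compound 1, `Fc1ccc(-c2cn3ccnc3c(-c3ccc4ncn(C5CCCCC5)c4c3)n2)cc1`, gives 9.54% in a functional assay on OVCAR-8 cells (Homo sapiens) for inhibition, read by sulforhodamine B assay, with a stated time of 48 h, tested at 10 uM; a higher number here means more inhibition at the concentration tested (going by the name of the read-out), a lower number less inhibition.
Compound 2, `Clc1ccc(-c2cn3ccnc3c(-c3ccc4ncn(C5CCCCC5)c4c3)n2)cc1`, gives 3.78% in this assay.
Compound 3, `c1csc(-c2cn3ccnc3c(-c3ccc4ncn(C5CCCCC5)c4c3)n2)c1`, gives 9.34% in this assay.

Compound 1 holds the highest of these three numbers, but the gap to compound 3 is only a number 0.2 percentage points lower from compound 1 to compound 3 (within the scatter) and the gap to compound 2 only a number 5.8 percentage points lower from compound 1 to compound 2 (within the scatter), so the three compounds cannot be told apart; all three give only weak inhibition at the concentration tested.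

Compound 4, `FC(F)(F)c1cccc(-c2cn3ccnc3c(-c3ccc4ncn(C5CCCCC5)c4c3)n2)c1`, has not yet been measured. It differs from compound 1 in one place: 3-(trifluoromethyl)phenyl in place of 4-fluorophenyl on an aromatic carbon.

Two of the measured steps bear on this change. The step from compound 1 to compound 2 changes only the halogen on the same aryl group, and the step from compound 1 to compound 3 replaces that aryl group altogether; each stayed within the scatter. A change in the substituent on the aryl group therefore seems unlikely to move the number beyond the scatter, and the step of a number 1.5 percentage points lower from compound 1 to compound 4 (within the scatter) is expected to be small. Compound 4 is estimated to give 8% in this assay, in a range from -2% to 22%.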

Compound 4, a percentage reported as inhibition, at one concentration (the size of the read-out at that concentration, not a potency): 10.1%
The estimate for compound 4 lay 2.1 percentage points below the measured number; the measured number falls inside the stated range.
By their numbers in this assay, from the lowest: compounds 2, 3, 1 and 4 (each within the scatter of the next).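

In this assay, the 3-(trifluoromethyl)phenyl group adds heavy atoms compared with 4-fluorophenyl and has its substituent at a different ring position, yet the result is a number 0.6 percentage points higher from compound 1 to compound 4 (within the scatter) for this change. Comparing the same group with the other two gives a number 0.8 percentage points higher from compound 3 to compound 4 (within the scatter) and a number 6.3 percentage points higher from compound 2 to compound 4 (within the scatter) as well, so a larger fluorinated aryl group at this position gives a number that cannot be told apart from those of the smaller aryl groups, and all four compounds remain a single group with weak inhibition at the concentration tested. Nothing measured here offers an explanation for this flat result.

Every group at this position in the compounds shown is an aromatic ring, so it remains open whether something of a different kind there, such as an amine, a carboxylic acid or a longer alkyl chain, would move the number beyond the scatter. The rest of the shared core is the same in all four compounds, so these results also say nothing about how changes elsewhere on the molecule would affect inhibition.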